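Replacing ethoxycarbonyl with hydroxymethyl: compound 3 to compound 4

The source may report more compounds than this note shows. Statements on the series, on what has been measured and on what is new or still open speak of the compounds shown alone.

Of the compounds shown here, three have been read in a functional assay on QGY cells (Homo sapiens) for cytotoxicity, read by MTT assay, with a stated time of 48 h; a higher number here means a weaker inhibitor, a lower number a stronger inhibitor. As far as these compounds go, compound 3 `CCOC(=O)[C@@]1(C(=O)Nc2ccccc2Cl)C[C@@H]1c1cc(OC)c(OC)c(OC)c1` returns only a limit, > 100000 nM, so its true position is unknown. The data so far are marked by the limit of > 100000 nM in this assay, at which 2 of the 3 values shown sit.

Compound 4 `COc1cc([C@H]2C[C@@]2(CO)C(=O)Nc2ccccc2Cl)cc(OC)c1OC` has hydroxymethyl in place of ethoxycarbonyl on a saturated ring carbon, with the change counted as hydroxymethyl in place of ethoxycarbonyl on a saturated ring carbon. Within the data shown here, no measured step changes one place alone, so the size of this change has to be judged from the two other compounds that carry hydroxymethyl.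

Compound 1 `COc1cc([C@@H]2C[C@]2(CO)C(=O)Nc2ccccc2Cl)cc(OC)c1OC` carries hydroxymethyl and gives a true number, 15700 nM, which points towards a stronger reading for compound 4. Compound 2 `COc1cc([C@H]2C[C@@]2(CO)C(=O)Nc2ccccc2)cc(OC)c1OC` also carries hydroxymethyl, yet it returns only a limit, > 100000 nM, and so goes against any rule that hydroxymethyl alone brings a measurable value.

A modest gain in potency is therefore expected, with a real chance that the reading again stops at the limit. The estimated step is an at least 2.2-fold lower number from compound 3 to compound 4 (0.34 log units; beyond the scatter). Compound 4 is estimated at 45000 nM, with an expected range of 12000 nM to 100000 nM.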

Compound 4, half-maximal inhibitory concentration: > 100000 nM
Compound 4 gave a limit, no number (the forecaster's own chance of this, stated with the estimate: 45%); at least 2.2-fold (0.34 log units) between middle value and limit.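

In this assay, compound 4 returns a limit and not a number, so hydroxymethyl in place of ethoxycarbonyl on a saturated ring carbon does not by itself bring a measurable value in this configuration, and the steps to compound 4 from compound 3 and from compound 2 cannot be read: the limit of > 100000 nM in this assay, at which 3 of the 4 values shown sit.

Among these compounds, the one readable comparison concerns configuration alone, with an at least 6.3-fold higher number from compound 1 to compound 4 (0.80 log units; beyond the scatter) while atoms and bonds stay the same. The measurable value seen so far in the hydroxymethyl compounds therefore goes with the configuration of compound 1, not with hydroxymethyl alone, and this is the first direct sign that configuration matters in this series: the fact that compounds 1 and 4 differ only in the configuration as drawn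

The compounds shown leave open whether ethoxycarbonyl also gives a number in the configuration of compound 1, and whether chloro is needed for a number in that configuration. Also open, as far as these compounds go, is whether an amine or a carboxylic acid in place of hydroxymethyl on that saturated ring carbon would keep a measurable value in this assay.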